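Removing the methoxy from compound 3: notes before measurement

The source may report more compounds than this note shows. Statements on the series, on what has been measured and on what is new or still open speak of the compounds shown alone.

Measured compounds in a functional assay on H9 cells (Homo sapiens); on this read-out lower numbers stand for stronger inhibition and higher numbers for weaker inhibition:
- compound 1, `CCC1(C)OC(/C(C)=C/COc2ccc3ccc(=O)oc3c2)=CC1=N`: 2.58 ug/mL
- compound 2, `C/C(=C\CO)CC1=CC(=O)C(C)(C)O1`: 9.13 ug/mL
- compound 3, `COc1ccccc1C1=CC(=O)CO1`: 66.3 ug/mL

Compound 3 stands at the highest number of the three. Its nearest neighbour is compound 2, whose number is lower by a gap beyond the scatter, and compound 1 lies further still, also beyond the scatter. Among the measured compounds shown here, the three compounds do not share a single-point change with one another, so no step between measured pairs is available, and the values show only where each compound sits.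

The next compound, compound 4, `O=C1C=C(c2ccccc2)OC1`, is to be measured in this assay. It differs from compound 3 in one place: hydrogen in place of methoxy on an aromatic carbon. The change is a hydrogen in place of a methoxy on an aromatic carbon of a six-membered aromatic ring of carbon only.

For the measured compounds named here, no measured step bears on this change. The expectation is a step of a 1.2-fold higher number from compound 3 to compound 4 (0.08 log units; within the scatter) of modest size, if any, most likely no change beyond the scatter, with a slight lean toward a higher number. Compound 4 is therefore estimated at 80 ug/mL, within a range from 25 ug/mL to 250 ug/mL.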

Compound 4, concentration for 50% inhibition: 38.6 ug/mL
Estimate against measurement, compound 4: 2.1-fold (0.32 log units) above, within the range that was stated.
By their numbers in this assay, from the lowest: compound 1; then compound 2; then compounds 4 and 3 (each within the scatter of the next).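

In this assay the exchange of methoxy for hydrogen gives a 1.7-fold lower number from compound 3 to compound 4 (0.23 log units; within the scatter) and so leaves the number within the scatter. Among the compounds shown here, this is the first step that isolates a single place: on this aromatic carbon, ortho to a group of 6 heavy atoms, the methoxy can be lost without a shift that can be told from repeat measurement, something the earlier compounds, which only showed where each one sits, could not show. Nothing on hand explains this outcome, and the step stands as an observation only.

One exchange on one carbon says little about this position as a whole, since only methoxy and hydrogen are shown there, and it remains open whether a larger or different group, such as an amine, a carboxylic acid or a longer alkoxy chain, would move the number beyond the scatter. As far as these compounds go, it also remains open whether a methoxy on another carbon of the same aromatic ring would behave in the same way.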